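Changing the benzyl arm of compound 3

The source may hold more compounds than are shown below. What is called first, only, known or untested is meant among the compounds shown, and "the series" means these compounds.

Compound 1 `Cc1c(Cc2ccccc2)c(=O)oc2cc(OCC(O)CNc3nccs3)ccc12` gives 93000 nM in an ADME assay on A549 cells (Homo sapiens) for cytotoxicity, read by CellTiter-Glo; a lower number here means that less compound is tolerated, a higher number that more compound is tolerated.
Compound 2 `Cc1ccc2nc(NCC(O)COc3ccc4c(C)c(Cc5ccccc5)c(=O)oc4c3)sc2c1` gives only a limit, > 100000 nM, in this assay.
Compound 3 `Cc1c(Cc2ccc(C(C)(C)C)cc2)c(=O)oc2cc(OCC(O)CN3CCC(C(N)=O)CC3)ccc12` gives 14700 nM in this assay.

Among the two numbers that are not limits, compound 3 has the lowest; the nearest, compound 1, lies higher by a gap beyond the scatter. Compound 2 sits at a limit of the assay (the limit of > 100000 nM in this assay, at which 1 of the 3 values shown sits), so its value cannot be ranked against the others.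

Compound 4 `COc1ccc(Cc2c(C)c3ccc(OCC(O)CN4CCC(C(N)=O)CC4)cc3oc2=O)c(Br)c1` is the next compound to be measured. It differs from compound 3 in one place: 2-bromo-4-methoxyphenyl in place of 4-(tert-butyl)phenyl on a saturated chain carbon bound to an aromatic carbon.

Among the measured compounds shown here, only one measured step is available, an at least 1.0-fold higher number from compound 1 to compound 2 (0.03 log units; that floor lies within the scatter), and it concerns a change on an amine nitrogen, not the benzyl arm that is altered here. For the measured compounds named here, no measured step therefore bears on the change from compound 3 to compound 4, and there is no basis for expecting a shift beyond the scatter in either direction. Compound 4 is accordingly expected to give about 18000 nM, with a range from 6000 nM to 55000 nM. This estimate means a step of a 1.2-fold higher number from compound 3 to compound 4 (0.09 log units; within the scatter), which is within the usual scatter.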

Compound 4, half-maximal cytotoxic concentration: 44400 nM
Compound 4: the middle estimate sits 2.5-fold (0.39 log units) below what was measured; low and high end bracket the measured number.
By their numbers in this assay, from the lowest: compound 3; then compound 4; then compound 1. At a limit, above all of these: compound 2.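

Among the compounds shown here, the benzyl arm is the first place where a single change gives a step clearly beyond the scatter: in this assay, putting 2-bromo-4-methoxyphenyl in place of 4-(tert-butyl)phenyl on the saturated chain carbon bound to an aromatic carbon means that more compound is tolerated (a 3.0-fold higher number from compound 3 to compound 4 (0.48 log units; beyond the scatter)). For the compounds shown here, this position therefore has a measurable bearing on the number, whereas the only earlier step, made on an amine nitrogen, has a floor within the scatter. The swap removes an all-carbon group of 10 heavy atoms and brings in one of 9 heavy atoms with an oxygen, a bromine and a hydrogen-bond acceptor, but nothing measured here explains why the number moves.

The two substituents change together, so the compounds shown leave open whether the bromo group, the methoxy group or the loss of the tert-butyl group accounts for the step. They also leave open how this arm would behave with a 4-aminophenyl or a 4-carboxyphenyl group in the same place, or with the same swap on the side chain of compound 1.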